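Swapping a Hydroxy for an Amino on a Shared Core

The compounds below may be only part of what the source reports. "The series", "measured", "known", "first", "only" and "open" are said of these compounds alone.

This study looks at three closely related compounds that share one core and differ only in small groups on its rings. Compound 1 `COc1ccc(-c2cc3ccccc3c(-c3cccc(N)c3)n2)cc1` carries an amino group and a plain methoxyphenyl; for compound 1 the entry in an assay on isolated protein for inhibition of DNA topoisomerase 1 (Homo sapiens), with a stated time of 30 min, tested at 20 uM (a lower number here means a weaker effect, a higher number a stronger effect of the compound at the concentration tested), reads "not determined" (no result reported), so it offers no number. For the measured compounds named here, compound 2 `COc1ccc(-c2cc3cc(C)ccc3c(-c3cccc(O)c3)n2)c(C)c1` adds two methyl groups and bears a hydroxy group instead; in this assay compound 2 gives 70.4%, which is the only number available, so it stands alone rather than in a ranked series.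

Compound 3 `COc1ccc(-c2cc3cc(C)ccc3c(-c3cccc(N)c3)n2)c(C)c1` is compound 2 with a single change: amino in place of hydroxy on an aromatic carbon. Going by the values given here, because only one number is known, no measured step between two compounds can be quoted, and the expectation rests on the closeness of the two groups alone. A hydroxy and an amino group are each counted as one heavy atom with one donor and one acceptor, so the expected step is small, with a slight lean downward, and may well sit inside the usual scatter; it is estimated as a number 10.4 percentage points lower from compound 2 to compound 3 (beyond the scatter). Compound 3 is therefore expected to reach about 60%, within a range from 30% to 85%.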

Compound 3, a percentage reported as inhibition, at one concentration (the size of the read-out at that concentration, not a potency): 72.4%
Compound 3: the middle estimate sits 12.4 percentage points below what was measured; low and high end bracket the measured number.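

Placing amino in place of hydroxy on the aromatic carbon gives a number 2 percentage points higher from compound 2 to compound 3 (within the scatter) in this assay, so the change from 3-hydroxyphenyl to 3-aminophenyl leaves the read-out inside the normal spread of repeat measurements. For the compounds shown here, this is the first pair here with numbers on both sides, and it shows that, in this assay and on this shared core, oxygen at this position can be exchanged for nitrogen with no difference that can be told from scatter. The data at hand offer no measurement that explains why the two groups read alike.

Each number comes from a single tested concentration, so the pair shows similar effects at that concentration and leaves open whether the two compounds would also read alike at other concentrations. As far as these compounds go, it also remains open whether this position accepts groups of a different kind, such as a carboxylic acid, an acetamide or a longer chain like aminomethyl, or a bare hydrogen, and what the two methyl groups contribute to the read-out.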